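Vinyl removal on the core of compound 2

The source may hold more compounds than are shown below. What is called first, only, known or untested is meant among the compounds shown, and "the series" means these compounds.

Measured so far:
compound 1 `Ic1nc2ccccc2[se]1`: > 40000 nM, a limit of the assay
compound 2 `C=Cc1nc2ccccc2n1C`: 2340 nM
compound 3 `C=Cc1nc2ccccc2s1`: > 40000 nM, a limit of the assay

Going by the values given here, in a functional assay on NCI-H522 cells (Homo sapiens) for cytotoxicity, with a stated time of 3 days (on this read-out higher numbers stand for weaker inhibition and lower numbers for stronger inhibition), compound 2 gives 2340 nM, the only number among the three results. For compound 1 the result of > 40000 nM is a limit and not a number. For compound 3 the result of > 40000 nM is likewise a limit. Among the compounds with values here, two of the three results therefore sit at the limit of > 40000 nM in this assay, at which 2 of the 3 values shown sit, so compound 2 is the one compound for which a number exists, and no comparison of its size with the others can be made.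

Compound 4 `Cn1cnc2ccccc21` differs from compound 2 by hydrogen in place of vinyl on an aromatic carbon. Within the data shown here, no measured pair shows this change, so the size of its effect in this assay is not known from the series. Among the measured compounds shown here, the vinyl is the feature that the only numbered compound, compound 2, carries, and its loss is expected to weaken inhibition: a step from compound 2 to compound 4 of an 11-fold higher number from compound 2 to compound 4 (1.03 log units; beyond the scatter) in this assay is estimated, beyond the scatter. Compound 4 is thus expected to give about 25000 nM in this assay, within 6000 nM to 40000 nM, with a fair chance that only a limit is reported.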

Compound 4, half-maximal inhibitory concentration: > 40000 nM
Compound 4 was reported as a limit; the forecaster's own chance of this, stated with the estimate: 55%; middle value at least 1.6-fold (0.20 log units) away from the limit.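

In this assay, hydrogen in place of vinyl on an aromatic carbon gives an at least 17-fold higher number from compound 2 to compound 4 (1.23 log units; beyond the scatter), the one pair shown that isolates this position, and the step is large. Going by these compounds alone, with the vinyl gone, the core of compound 2 no longer gives a number, so in this pair the measurable cytotoxicity depends on the vinyl, which the earlier compounds alone could not show. For compound 4 the result of > 40000 nM is a limit, and the full size of the step cannot be read because compound 4 stands at this limit: the limit of > 40000 nM in this assay, at which 3 of the 4 values shown sit.

The compounds shown leave open whether the double bond of the vinyl matters or whether another group on this aromatic carbon, such as an ethyl, a longer chain, an amine or a carboxylic acid, would also keep a measurable result. Also open, as far as these compounds go, is how the result of compound 2, 2340 nM, would respond to an ethyl in place of the methyl group on the neighbouring ring atom.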